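The compounds below may be only part of what the source reports. "The series", "measured", "known", "first", "only" and "open" are said of these compounds alone.

Measured in a functional assay on CHO-K1 cells for agonist activity at Glucose-dependent insulinotropic receptor (Homo sapiens), read by cAMP accumulation and immunoassay, with a stated time of 1 h; a higher number here means that more compound is needed for the effect, a lower number that less compound is needed:
Compound 1 `COC(=O)N1CCC(Oc2ncnc(Oc3ccc(/C=C4\SC(=O)NC4=O)cc3)c2C)CC1`: 1410 nM
Compound 2 `Cc1c(Oc2ccc(/C=C3\SC(=O)NC3=O)cc2)ncnc1OC1CCN(C(=O)OCc2ccccc2)CC1`: 805 nM

Compound 2 gives the lower of the two numbers, though the step of a 1.8-fold lower number from compound 1 to compound 2 (0.24 log units; within the scatter) is covered by the scatter; it came from a phenyl in place of hydrogen on a saturated chain carbon bound to an oxygen next to a carbonyl group. Compound 3 `O=C1NC(=O)/C(=C/c2ccc(Oc3cc(OC4CCN(C(=O)OCc5ccccc5)CC4)ncn3)cc2)S1` differs from compound 2 by hydrogen in place of methyl on an aromatic carbon. Going by the values given here, no measured step touches that ring position, so the data give no guide to what the methyl contributes. A step of a 1.2-fold higher number from compound 2 to compound 3 (0.09 log units; within the scatter) is expected, nothing beyond the scatter. Compound 3 is estimated at 1000 nM, between 300 nM and 3500 nM.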

Compound 3, half-maximal effective concentration: 107 nM
For compound 3 the middle estimate is 9.3-fold (0.97 log units) above the measured one; the whole stated range lies above it.
By their numbers in this assay, from the lowest: compound 3; then compounds 2 and 1 (each within the scatter of the next).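

In this assay, this ring carbon, ortho to two large groups and two atoms from the ring nitrogen, proves sensitive: hydrogen in place of methyl gives a 7.5-fold lower number from compound 2 to compound 3 (0.88 log units; beyond the scatter), so less compound is needed without the methyl. The earlier change, a 1.8-fold lower number from compound 1 to compound 2 (0.24 log units; within the scatter), stayed within the scatter, which makes this the first step shown to go beyond it. No measured evidence here explains the shift.

From the compounds shown here alone, whether ethyl, chlorine or an amine at this carbon would give a lower or higher number remains open. Also open, going by these compounds, is whether hydrogen in place of methyl would give a step of this size on compound 1.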